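This account rests on a few compounds, and the source may have more. Where it says the series, first, only, none or still open, it means among the compounds named here.

Measured in an ADME assay on SH-SY5Y cells (Homo sapiens) for cytotoxicity, read by MTT assay, with a stated time of 72 h; a higher number here means that more compound is tolerated, a lower number that less compound is tolerated:
Compound 1 `c1ccc(-c2cn3cc(-c4ccco4)ccc3n2)cc1`: > 100000 nM
Compound 2 `c1coc(-c2ccc3nc(-c4ccco4)cn3c2)c1`: 3000 nM

Compound 1 stands only at a limit of this assay, > 100000 nM, so there is no number for it. Compound 3 `Nc1cc(-c2ccco2)cn2cc(-c3ccccc3)nc12` keeps the core of compound 1 and differs from it as follows: amino in place of hydrogen on an aromatic carbon.

Within the data shown here, no measured step covers amino in place of hydrogen. The nearest evidence is an at least 33-fold lower number from compound 1 to compound 2 (1.52 log units; beyond the scatter), a large step beyond the scatter, but it comes from a different change, furan-2-yl in place of phenyl. Among the measured compounds shown here, it shows only that a single change can lower the number strongly from compound 1, so a smaller step in the same direction is expected here, with a real chance of staying at the limit. The expected step is an at least 2.5-fold lower number from compound 1 to compound 3 (0.39 log units; beyond the scatter). For compound 3 the estimate is 40000 nM, with an expected range of 8000 nM to 100000 nM.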

Compound 3, half-maximal cytotoxic concentration: 26000 nM
Compound 3: middle estimate off by 1.5-fold (0.19 log units), on the high side; the range from low to high includes it.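

In this assay, amino in place of hydrogen gives an at least 3.8-fold lower number from compound 1 to compound 3 (0.58 log units; beyond the scatter). Among these compounds, this is the first reading at this position, on an aromatic carbon two atoms from the ring nitrogen, and it shows that a change away from the phenyl and furan-2-yl groups can also lower the number from compound 1, with compound 3 giving a measured value. Compound 1 stands at a limit, so only the least possible size of this step is known, and the real size stays open: the limit of > 100000 nM in this assay, at which 1 of the 3 values shown sits.

From the compounds shown here alone, whether a methyl group, a hydroxyl group or an acetamide on the same carbon moves the number in the same direction as amino remains open. Also open is how amino on this carbon acts together with the furan-2-yl in place of phenyl, since no compound shown carries both changes.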